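Moving an acetyl group around a thiophene

The source may report more compounds than this note shows. Statements on the series, on what has been measured and on what is new or still open speak of the compounds shown alone.

- compound 1 `Cc1ccc(-c2cncc(Cl)c2N2CCC3(CCNC3=O)CC2)o1`: 4950 nM
- compound 2 `Cc1ccsc1-c1cncc(Cl)c1N1CCC2(CCNC2=O)CC1`: 910 nM
- compound 3 `CC(=O)c1ccc(-c2cncc(Cl)c2N2CCC3(CCNC3=O)CC2)s1`: 1440 nM

These three compounds share one core and differ only in the ring group attached to it. In a functional assay on MV4-11 cells (Homo sapiens) for inhibition, read by resazurin assay, with a stated time of 72 h (on this read-out lower numbers stand for stronger inhibition of growth and higher numbers for weaker inhibition of growth), compound 3 gives 1440 nM. Among the compounds with values here, that value cannot be told apart from the one for compound 2, as the step shows: a 1.6-fold higher number from compound 2 to compound 3 (0.20 log units; within the scatter). Compared with compound 1, compound 3 has a clearly lower number: a 3.4-fold lower number from compound 1 to compound 3 (0.54 log units; beyond the scatter).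

The next compound, compound 4 `CC(=O)c1sccc1-c1cncc(Cl)c1N1CCC2(CCNC2=O)CC1`, contains the same atoms joined differently: 2-acetylthiophen-3-yl in place of 5-acetylthiophen-2-yl on an aromatic carbon. Here 2-acetylthiophen-3-yl takes the place of 5-acetylthiophen-2-yl.

Within the data shown here, no measured step shows this exact kind of rearrangement, so the evidence is indirect. Replacing the furan group of compound 1 gave modest steps: a 5.4-fold lower number from compound 1 to compound 2 (0.74 log units; beyond the scatter), and a 3.4-fold lower number from compound 1 to compound 3 (0.54 log units; beyond the scatter). Between the two thiophene compounds, however, compound 2 and compound 3, the different group made no difference beyond the scatter. Since compound 4 is also a thiophene compound, this last comparison is the closest guide. The expected step is a 1.0-fold higher number from compound 3 to compound 4 (0.02 log units; within the scatter), so no change beyond the scatter is expected, although the uncertainty is wide. For compound 4 the estimated value is 1500 nM, with an expected range from 500 nM to 4500 nM.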

Compound 4, concentration for 50% growth inhibition: > 100000 nM
Compound 4: no number, only a limit (the forecaster's own chance of this, stated with the estimate: 5%); middle value at least 66-fold (1.82 log units) away from the limit.
By their numbers in this assay, from the lowest: compounds 2 and 3 (each within the scatter of the next); then compound 1. At a limit, above all of these: compound 4.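

In this assay compound 4 gives > 100000 nM, which is a limit of the assay and not a number. The change keeps every atom and only rearranges the acetylthiophene on an aromatic carbon ortho to a large group, yet it produces a large step, an at least 69-fold higher number from compound 3 to compound 4 (1.84 log units; beyond the scatter), so at this position the way the group is joined can matter far more than the earlier swaps suggested. The other comparisons are also large, an at least 100-fold higher number from compound 2 to compound 4 (2.04 log units; beyond the scatter) and an at least 20-fold higher number from compound 1 to compound 4 (1.30 log units; beyond the scatter), whereas the steps among compounds 1, 2 and 3 were modest or within the scatter, so the 2-acetylthiophen-3-yl group stands apart from all three other groups in this set.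

These compounds cannot separate the contribution of the acetyl group from that of a thiophene joined through this ring carbon, and a thiophen-3-yl group carrying a methyl or an amine in place of the acetyl would address that question. They also give no explanation for the drop, and the limit leaves the true size of each step open.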